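Replacing a Ring With a Chain on a Sulfonyl Tail

This account rests on a few compounds, and the source may have more. Where it says the series, first, only, none or still open, it means among the compounds named here.

Measured compounds:
compound 1, `C=CCCCCCCS(=O)(=O)/C=C/c1ccc(O)c(O)c1` — 6400 nM
compound 2, `O=S(=O)(/C=C/c1ccc(O)c(O)c1)CCCC1CCCCC1` — 7900 nM

Both compounds were tested in a functional assay, read by fluorescence and spectrophotometry, with a stated time of 1 h; a higher number here means that more compound is needed for the effect, a lower number that less compound is needed. Within the data shown here, compound 2 gives the highest of the two numbers, but its only neighbour, compound 1, lies within the scatter, so the two cannot be told apart. Among the measured compounds shown here, the single measured step, a 1.2-fold higher number from compound 1 to compound 2 (0.09 log units; within the scatter), alters the tail on a saturated chain carbon, three bonds along the chain from a sulfonyl sulfur, and leaves the number essentially where it was.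

Compound 3, `CCCCCCCCCCCS(=O)(=O)/C=C/c1ccc(O)c(O)c1`, is not yet measured. It differs from compound 2 in one place: octyl in place of cyclohexyl on a saturated chain carbon, three bonds along the chain from a sulfonyl sulfur. For the measured compounds named here, the one step that bears on this, a 1.2-fold higher number from compound 1 to compound 2 (0.09 log units; within the scatter), also exchanged a chain fragment for a ring at the same spot and stayed within the scatter; the reverse exchange here gives no reason to expect anything larger. The step from compound 2 to compound 3 is therefore expected to be a 1.1-fold lower number from compound 2 to compound 3 (0.05 log units; within the scatter), within the scatter. Compound 3 is estimated at 7000 nM, with a range of 3500 nM to 14000 nM in this assay.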

Compound 3, half-maximal effective concentration: 11400 nM
For compound 3 the middle estimate is 1.6-fold (0.21 log units) below the measured one; the range from low to high includes it.
By their numbers in this assay, from the lowest: compounds 1, 2 and 3 (each within the scatter of the next).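

In this assay, the tail on a saturated chain carbon, three bonds along the chain from a sulfonyl sulfur, can now be compared as a ring and as a fully saturated straight chain: octyl in place of cyclohexyl gives a 1.4-fold higher number from compound 2 to compound 3 (0.16 log units; within the scatter), so this pair cannot be told apart and losing the ring has no effect that can be read here. The other new comparison concerns the far end of the chain, where pentyl in place of vinyl, on a saturated chain carbon, six bonds along the chain from a sulfonyl sulfur, gives a 1.8-fold higher number from compound 1 to compound 3 (0.25 log units; within the scatter), so the double bond at the chain's end likewise makes no readable difference. No separate measurement bears on why these tails behave so alike.

On these data alone, all three tails contain carbon only, so it remains open whether an amine or a carboxylic acid at the end of the chain would move the number beyond the scatter. As far as these compounds go, it is also open whether a much shorter chain, or one longer than octyl, would do so on the same core.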